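The source may hold more compounds than are shown below. What is called first, only, known or untested is meant among the compounds shown, and "the series" means these compounds.

Among the measured compounds shown here, in a functional assay on Raji cells (Homo sapiens) for cytotoxicity, read by CCK-8 assay, with a stated time of 24 h (on this read-out lower numbers stand for stronger inhibition and higher numbers for weaker inhibition), compound 1 `C=CC(=O)N1C(=O)CCSc2ccccc21` gives 581000 nM, the higher of the two numbers so far, while compound 2 `C=CC(=O)N1C(=O)CC(c2ccccc2C(F)(F)F)Sc2ccccc21` gives 50300 nM, a lower number by more than the usual scatter. Compound 3 `C=CC(=O)N1C(=O)CC(c2ccc(C#N)cc2)Sc2ccccc21` keeps the core of compound 1 with one change: 4-cyanophenyl in place of hydrogen on a saturated ring carbon, next to the ring sulfur. Going by compound 2 at 50300 nM, a large drop in the number, beyond the scatter, is expected. The estimated step is a 12-fold lower number from compound 1 to compound 3 (1.07 log units; beyond the scatter). For compound 3 the expected value is 50000 nM, with an estimated range of 15000 nM to 170000 nM.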

Compound 3, half-maximal inhibitory concentration: 84500 nM
Compound 3: middle estimate off by 1.7-fold (0.23 log units), on the low side; the measured number falls inside the stated range.
By their numbers in this assay, from the lowest: compounds 2 and 3 (each within the scatter of the next); then compound 1.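

Placing 4-cyanophenyl in place of hydrogen on this saturated ring carbon gives a 6.9-fold lower number from compound 1 to compound 3 (0.84 log units; beyond the scatter), so the fall seen with compound 2 is not confined to its trifluoromethyl-bearing ring. Compound 2 and compound 3 lie within the usual scatter of each other, so these two ring substituents cannot be told apart here. No measurement shown explains the drop.

Still open, going by these compounds, is whether a ring is needed at this carbon at all, or whether a methyl group would do the same. Also open, on these data alone, is how a carboxylic acid or an amine on the phenyl ring would fare.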